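This account rests on a few compounds, and the source may have more. Where it says the series, first, only, none or still open, it means among the compounds named here.

Measured so far:
compound 1 `CN(C)c1c(C#N)c2c(N)ncnc2n1C`: 111 nM
compound 2 `C[C@@H]1CCCN1c1cc2c(N)ncnc2n1C`: 164 nM

Both numbers come from an assay on isolated protein for binding affinity to Leucine-rich repeat serine/threonine-protein kinase 2 (Homo sapiens), read by TR-FRET and LanthaScreen, with a stated time of 2 h; on this read-out lower numbers stand for stronger inhibition and higher numbers for weaker inhibition. Compound 1 gives the lower of the two numbers, but compound 2 sits within the scatter of it, so the two measured compounds are not set apart from each other on this read-out.

Compound 3 `Cn1c(-c2ccccc2)c(C#N)c2c(N)ncnc21` is not yet measured. It differs from compound 1 in one place: phenyl in place of dimethylamino on an aromatic carbon. For the measured compounds named here, no pair of measured compounds shows a step of this kind, so there is no measured step to calibrate it against; compound 1 and compound 2 differ in more than one place, and their two values show nothing beyond the scatter. With no calibration, the step from compound 1 to compound 3 in this assay is expected to be a 1.4-fold higher number from compound 1 to compound 3 (0.13 log units; within the scatter), that is, no change beyond the scatter, with the range kept wide in both directions. Compound 3 is accordingly estimated at 150 nM in this assay, within 40 nM to 600 nM.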

Compound 3, inhibition constant: 30 nM
Compound 3: middle estimate off by 5.0-fold (0.70 log units), on the high side; the whole stated range lies above it.
By their numbers in this assay, from the lowest: compound 3; then compounds 1 and 2 (each within the scatter of the next).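

With phenyl in place of dimethylamino on this aromatic carbon, next to the ring nitrogen, this assay shows a 3.7-fold lower number from compound 1 to compound 3 (0.57 log units; beyond the scatter) and gives the series its first step beyond the scatter. The read-out therefore responds to the group at this position, and a six-membered aromatic ring of carbon only is accepted there in place of the smaller, ring-free dimethylamino, though this single modest step gives a direction for this pair alone. Nothing at hand accounts for the step.

Open, going by these compounds, is whether the gain needs an aromatic ring at all, which a saturated ring such as cyclohexyl would test against phenyl, and whether a ring nitrogen, as in pyridyl, or a methoxy group on the phenyl would keep it. Also open, on these data alone, is whether the same step would hold with hydrogen in place of the cyano group on the neighbouring ring atom.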